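Compound 3 to compound 4: one methyl fewer

A few compounds are considered here, and "the series" means these few. Any claim that something is new, unique, unknown or untested is made for them only; others in the source may bear on it.

Measured in an ADME assay on Huh-7 cells (Homo sapiens) for cytotoxicity, read by MTT assay, with a stated time of 4 h, at 37 degrees C; a higher number here means that more compound is tolerated, a lower number that less compound is tolerated:
- compound 1 `COCCn1c(=O)c(-c2c(Cl)cccc2Cl)cc2c(N)nc(Nc3ccccc3)nc21` at 241000 nM
- compound 2 `CCCCCNc1nc(N)nc2c1cc(-c1ccc(F)cc1)c(=O)n2C` at 79800 nM
- compound 3 `CC(C)Cn1c(=O)c(-c2c(Cl)cccc2Cl)cc2c(N)nc(Nc3ccccc3)nc21` at 185000 nM

Compound 3, at 185000 nM, lies level with compound 1 within the scatter and clear of compound 2 on the higher side. Compound 4 `CCCn1c(=O)c(-c2c(Cl)cccc2Cl)cc2c(N)nc(Nc3ccccc3)nc21` is the next case: hydrogen in place of methyl on a saturated chain carbon bound to two saturated chain carbons. This places hydrogen in place of methyl on a saturated chain carbon bound to two saturated chain carbons, turning isobutyl to propyl. Among the measured compounds shown here, one measured step bears on this chain, a 1.3-fold lower number from compound 1 to compound 3 (0.11 log units; within the scatter), and it stays within the scatter. No step beyond the scatter is therefore expected in this assay. The expected change is a 1.1-fold higher number from compound 3 to compound 4 (0.02 log units; within the scatter). For compound 4 the estimate is 195000 nM, with an expected range of 105000 nM to 340000 nM.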

Compound 4, half-maximal cytotoxic concentration: 181000 nM
Estimate against measurement, compound 4: 1.1-fold (0.03 log units) above; measured number inside the range.
By their numbers in this assay, from the lowest: compound 2; then compounds 4, 3 and 1 (each within the scatter of the next).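

Going from isobutyl to propyl in this assay gives a small step (a 1.0-fold lower number from compound 3 to compound 4 (0.01 log units; within the scatter)), so this chain loses the methyl without a move beyond the scatter. Methyl in place of methoxy gives a step of similar standing (a 1.3-fold lower number from compound 1 to compound 4 (0.12 log units; within the scatter)), which leaves the chains of compound 1, compound 3 and compound 4 level with one another. No available evidence offers an explanation for this flat reading.

On these data alone, whether an amine, a carboxylic acid or a much longer chain at this place would produce a step beyond the scatter remains open.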